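The source may hold more compounds than are shown below. What is called first, only, known or untested is meant among the compounds shown, and "the series" means these compounds.

Series in a functional assay on MDA-MB-231 cells (Homo sapiens), read by microscopy and transwell migration, with a stated time of 24 h; on this read-out higher numbers stand for weaker inhibition and lower numbers for stronger inhibition:
- Compound 1 `COc1cc(-c2csc(NC(=O)c3ccc(Cl)cc3)n2)cc(OC)c1OC`: > 25000 nM, a limit
- Compound 2 `COc1ccc(C(=O)Nc2nc(-c3cc(OC)c(OC)c(OC)c3)cs2)cc1OC`: > 25000 nM, a limit
- Compound 3 `COc1cc(C(=O)Nc2nc(-c3cc(OC)c(OC)c(OC)c3)cs2)cc(OC)c1OC`: not yet measured

Compound 2 stands only at its limit of > 25000 nM. The evidence so far is the limit of > 25000 nM in this assay, at which 2 of the 2 values shown sit. Compound 3 adds methoxy in place of hydrogen on an aromatic carbon, ortho to a methoxy group. For the measured compounds named here, the only measured step, a step that the two limits leave unreadable from compound 1 to compound 2, gives neither size nor direction to carry over. No step beyond the scatter is therefore expected in this assay, and the expected step is a number no higher from compound 2 to compound 3 (the limit leaves the size open). The estimated value for compound 3 is 25000 nM, with an expected range of 6000 nM to 50000 nM.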

Compound 3, half-maximal inhibitory concentration: 1030 nM
Compound 3: middle estimate off by 24-fold (1.39 log units), on the high side, outside the stated range (below it).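

In this assay, methoxy in place of hydrogen on an aromatic carbon, ortho to a methoxy group, gives an at least 24-fold lower number from compound 2 to compound 3 (1.38 log units; beyond the scatter). For the compounds shown here, the earlier step between two limits cannot be read, so this is the first sign that the substitution pattern on this ring changes the read-out. The size of the step stays open, as compound 2 stands only at a limit: the limit of > 25000 nM in this assay, at which 2 of the 3 values shown sit.

As far as these compounds go, whether methoxy itself is needed at this carbon stays open. A hydroxyl, an ethoxy group or an amine there could give a different result.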